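Trimming the sulfonyl aryl group of compound 1

The source may hold more compounds than are shown below. What is called first, only, known or untested is meant among the compounds shown, and "the series" means these compounds.

Compound 1 `COc1ccc(S(=O)(=O)c2cnc3ccc(C)cc3c2N2CCC(C)CC2)cc1Cl` stands highest of the two numbers in hand: in an assay on isolated protein for displacement of a labelled ligand from metabotropic glutamate receptor 5 (Homo sapiens), with a stated time of 60 min, tested at 1 uM (on this read-out lower numbers stand for less inhibition and higher numbers for more inhibition at the one concentration tested (going by the name of the read-out)), compound 1 gives 93%. Going by the values given here, its only neighbour, compound 2 `COc1ccc2ncc(S(=O)(=O)c3ccc(OC)c(Cl)c3)c(N3CCC(C)CC3)c2c1`, differs from it by methoxy in place of methyl on an aromatic carbon and gives 21% in this assay, a step of a number 72 percentage points lower from compound 1 to compound 2 (beyond the scatter). The unmeasured compound 3 `Cc1ccc2ncc(S(=O)(=O)c3ccccc3)c(N3CCC(C)CC3)c2c1` departs from compound 1 at a different place: phenyl in place of 3-chloro-4-methoxyphenyl on a sulfonyl sulfur. Among the compounds with values here, the one measured step varies the core and not the group on the sulfonyl sulfur, so no measured step bears directly on this change, and no comparison in hand varies the 3-chloro-4-methoxyphenyl at all. With the chlorine and the oxygen of that group gone, a downward step beyond the scatter is expected, but its size is open. Compound 3 is expected to give 60% in this assay, within 20% to 92%, an estimated step of a number 33 percentage points lower from compound 1 to compound 3 (beyond the scatter).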

Compound 3, a percentage reported as inhibition, at one concentration (the size of the read-out at that concentration, not a potency): 67%
Compound 3: the middle estimate sits 7 percentage points below what was measured, and the stated range covers the measured number.
By their numbers in this assay, from the lowest: compound 2; then compound 3; then compound 1.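

Going by these compounds alone, replacing 3-chloro-4-methoxyphenyl with phenyl on the sulfonyl sulfur is the first measured change at this place, and in this assay it gives a number 26 percentage points lower from compound 1 to compound 3 (beyond the scatter). The group on the sulfonyl sulfur therefore counts towards the read-out, yet the step is modest, and the plain phenyl still leaves compound 3 at 67% at the one concentration tested. Nothing measured here explains the size of this step.

The chlorine and the methoxy leave together, so the compounds shown do not separate their shares, which a phenyl carrying only the chlorine or only the methoxy would do. Also open, going by these compounds, are how a pyridine ring or an amine-bearing phenyl would fare on the sulfonyl sulfur, and whether this step would hold on the core of compound 2.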